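Swapping the nitro-bearing aryl for a difluorophenyl

This account rests on a few compounds, and the source may have more. Where it says the series, first, only, none or still open, it means among the compounds named here.

The series shares one core, a vinyl sulfone bearing a bromophenyl ketone, and differs only in the aryl groups at its ends. Compound 1 `O=C(/C(=C\c1ccc(F)c([N+](=O)[O-])c1)S(=O)(=O)c1ccc(Br)cc1)c1ccc(Br)cc1` carries a 4-fluoro-3-nitrophenyl on the double bond; in a functional assay on DU-145 cells (Homo sapiens) for inhibition, read by trypan blue exclusion, with a stated time of 96 h (on this read-out higher numbers stand for weaker inhibition of growth and lower numbers for stronger inhibition of growth), compound 1 gives 25000 nM, the highest of the two numbers recorded. Compound 2 `COc1ccc(S(=O)(=O)/C(=C/c2ccc(Br)cc2)C(=O)c2ccc(Br)cc2)cc1`, with a bromophenyl on the double bond and a methoxyphenyl sulfone, gives 6000 nM in this assay, a difference from compound 1 beyond the scatter.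

Compound 3 `O=C(/C(=C\c1ccc(F)cc1F)S(=O)(=O)c1ccc(Br)cc1)c1ccc(Br)cc1` has not been measured. It differs from compound 1 in one place: 2,4-difluorophenyl in place of 4-fluoro-3-nitrophenyl on a double-bonded chain carbon bound to a double-bonded chain carbon. Among the compounds with values here, compound 2 is not a single-change neighbour of either, so no measured step guides this change directly. Two cases are too few to claim a trend. The difluorophenyl is expected to leave the number near that of compound 1 or move it modestly lower, with the step of a 2.1-fold lower number from compound 1 to compound 3 (0.32 log units; beyond the scatter) expected to lie close to the edge of the scatter. Compound 3 is therefore estimated at 12000 nM, within 4000 nM to 40000 nM.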

Compound 3, concentration for 50% growth inhibition: 7500 nM
Compound 3: middle estimate off by 1.6-fold (0.20 log units), on the high side; low and high end bracket the measured number.
By their numbers in this assay, from the lowest: compounds 2 and 3 (each within the scatter of the next); then compound 1.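

In this assay, the change gives the series its first measured step, a 3.3-fold lower number from compound 1 to compound 3 (0.52 log units; beyond the scatter): the aryl group on a double-bonded chain carbon bound to a double-bonded chain carbon does bear on the number, and 2,4-difluorophenyl in place of 4-fluoro-3-nitrophenyl moves it towards stronger inhibition of growth. The group that leaves has 10 heavy atoms and 2 hydrogen-bond acceptors, and the group that enters has 8 heavy atoms and 0 hydrogen-bond acceptors, but this single step cannot separate the loss of the nitro group from the gain of the second fluorine. Nothing measured here speaks to why the number moves.

The compounds shown leave open whether the same step would appear with the methoxyphenyl sulfone of compound 2 in place of the bromophenyl sulfone, as only this one pair differs in one place. They also leave open how the number would respond to an amine or a carboxylic acid on the aryl group at this position, or to a phenyl group carrying a single fluorine.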